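This account rests on a few compounds, and the source may have more. Where it says the series, first, only, none or still open, it means among the compounds named here.

Compound 1, with the structure `O=C1C[C@H](O)C[C@@H](/C=C/c2cnc3ccccc3c2Sc2ccc(F)cc2)O1`, is one of two compounds for which numbers exist in an assay (strain Holtzman-Sprague-Dawley) for inhibition of 3-hydroxy-3-methylglutaryl-coenzyme A reductase (Rattus norvegicus), with a stated time of 30 min; on this read-out lower numbers stand for stronger inhibition and higher numbers for weaker inhibition. There compound 1 gives 18600 nM, the lower of the two numbers. For the measured compounds named here, the other measured compound is compound 2, with the structure `COc1cccc(Sc2c(F)cc3c(Sc4cccc(OC)c4)c(/C=C/[C@@H]4C[C@@H](O)CC(=O)O4)cnc3c2Sc2cccc(OC)c2)c1`, which in this assay gives 74600 nM; the two structures differ in several places at once, so their values show only that compound 2 sits well beyond the scatter on the weaker side of compound 1. Compound 3, with the structure `CC(C)c1ccc(Sc2c(/C=C/[C@@H]3C[C@@H](O)CC(=O)O3)cnc3ccccc23)cc1`, differs from compound 1 in one place: isopropyl in place of fluoro on an aromatic carbon, para to a large group. Going by the values given here, no measured pair shows this change, so the expectation rests on the shared core alone: a small step toward weaker inhibition is expected, a 1.5-fold higher number from compound 1 to compound 3 (0.18 log units; within the scatter), barely beyond the scatter. Compound 3 is therefore estimated at 28000 nM, with a range from 9000 nM to 90000 nM.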

Compound 3, half-maximal inhibitory concentration: 12700 nM
Compound 3: middle estimate off by 2.2-fold (0.34 log units), on the high side; the measured number falls inside the stated range.
By their numbers in this assay, from the lowest: compounds 3 and 1 (each within the scatter of the next); then compound 2.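

In this assay, isopropyl in place of fluoro on an aromatic carbon, para to a large group, gives a 1.5-fold lower number from compound 1 to compound 3 (0.17 log units; within the scatter) and so leaves the two compounds indistinguishable. This is the only one-place comparison shown, and it suggests that, on the shared core, this position can hold a group of three heavy atoms instead of a single heavy atom with no change that the assay can resolve. Nothing available bears on why the two groups give such similar numbers.

Going by these compounds, only these two groups are compared at this position, so it remains open whether an amine, a carboxylic acid or a longer chain there would shift the number beyond the scatter. Compound 2 differs from compound 1 and compound 3 in several places, so it cannot settle this question.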